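A few compounds are considered here, and "the series" means these few. Any claim that something is new, unique, unknown or untested is made for them only; others in the source may bear on it.

In a physicochemical assay for solubility (on this read-out lower numbers stand for lower solubility and higher numbers for higher solubility), compound 1 `CNC(=O)c1cc(C(=O)N[C@H]2[C@@H]3COC[C@@H]32)cc2c1OC[C@H]2c1ccccc1` gives >= 165 ug/mL as a limit, not a number. Compound 2 `CNC(=O)c1cc(C(=O)N[C@H]2[C@@H]3C[C@@H](O)C[C@@H]32)cc2c1OC[C@H]2c1ccccc1` gives >= 124 ug/mL as a limit too, so its position is bounded on one side only. Compound 3 `CNC(=O)c1cc(C(=O)NC2CC2)cc2c1OC[C@H]2c1cccc(F)c1` gives >= 175 ug/mL, again a limit. All three values shown for the series are therefore limits.

The next structure is compound 4 `CNC(=O)c1cc(C(N)=O)cc2c1OC[C@H]2c1ccccc1`. The change is a hydrogen atom in place of a group of 7 heavy atoms (6 carbon, 1 oxygen; one three-membered non-aromatic ring of carbon only, one five-membered non-aromatic ring of carbon only), on an amide-type nitrogen, which leaves the amide-type nitrogen bonded to the carbonyl carbon and a hydrogen atom.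

For the measured compounds named here, the one measured step at this nitrogen is a step that the two limits leave unreadable from compound 1 to compound 2 and offers no size to carry over. Going by the values given here, compound 3 differs from the others in more than one place and supplies no step.

As far as these compounds go, with no readable step, no shift beyond the scatter is expected in this assay, and the direction remains open. The expected step is a step that the limit leaves unreadable from compound 2 to compound 4 as an estimate only. For compound 4 the estimated value is 150 ug/mL with an expected range of 60 ug/mL to 220 ug/mL in this assay.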

Compound 4, solubility: >= 144 ug/mL
Compound 4: a limit, no number; the forecaster's own chance of this, stated with the estimate: 60%; the middle value lies beyond the limit too.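

In this assay compound 4 gives >= 144 ug/mL, a limit and not a number. With limits on both sides, the steps from compound 1 and from compound 2 to compound 4 cannot be read. The compounds shown leave open the size and direction of any change when hydrogen replaces either group on the amide-type nitrogen.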